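The source may report more compounds than this note shows. Statements on the series, on what has been measured and on what is new or still open speak of the compounds shown alone.

In a functional assay on HeLa cells (Homo sapiens) for inhibition (a higher number here means a weaker inhibitor, a lower number a stronger inhibitor), three compounds sharing one core have been measured, each with a different group on an aromatic carbon. Compound 1 `O=C1C=CC(OCC(F)(F)F)N1c1ccc(C(F)(F)F)cc1`, with trifluoromethyl, gives 36200 nM. Compound 2 `Cc1ccc(N2C(=O)C=CC2OCC(F)(F)F)cc1`, with methyl, gives 9380 nM. Compound 3 `CCc1ccc(N2C(=O)C=CC2OCC(F)(F)F)cc1`, with ethyl, gives 6510 nM. Its gap to the methyl compound lies within the scatter, as a 1.4-fold lower number from compound 2 to compound 3 (0.16 log units; within the scatter) shows, so those two numbers cannot be ranked. The gap to the trifluoromethyl compound lies beyond it: a 5.6-fold lower number from compound 1 to compound 3 (0.75 log units; beyond the scatter).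

The next compound, compound 4 `O=C1C=CC(OCC(F)(F)F)N1c1ccc([N+](=O)[O-])cc1`, has nitro in place of ethyl on an aromatic carbon, para to a large group: nitro in place of ethyl on an aromatic carbon. Going by the values given here, no nitro compound has been measured, so the guide is indirect. The closest evidence is compound 1, whose trifluoromethyl, like nitro, is no plain alkyl group. Replacing it gave modest steps, a 3.9-fold lower number from compound 1 to compound 2 (0.59 log units; beyond the scatter) and a 5.6-fold lower number from compound 1 to compound 3 (0.75 log units; beyond the scatter). Leaving ethyl for nitro is therefore expected to run the opposite way, towards a higher number, by a similarly modest amount. This rests on a single comparison, so the range is kept wide. For compound 4 the estimated value is 20000 nM, with an expected range from 7000 nM to 50000 nM. The expected change is a 3.1-fold higher number from compound 3 to compound 4 (0.49 log units; beyond the scatter).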

Compound 4, half-maximal inhibitory concentration: 2380 nM
Beside the measured number, compound 4's estimate is 8.4-fold (0.92 log units) above it; measured number below the stated range.
By their numbers in this assay, from the lowest: compound 4; then compounds 3 and 2 (each within the scatter of the next); then compound 1.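

In this assay, putting nitro in place of ethyl on this aromatic carbon, para to a large group, lowers the number rather than raising it (a 2.7-fold lower number from compound 3 to compound 4 (0.44 log units; beyond the scatter)), and the gap to the methyl compound is also beyond the scatter (a 3.9-fold lower number from compound 2 to compound 4 (0.60 log units; beyond the scatter)), which makes compound 4 the strongest inhibitor of the four. The change from trifluoromethyl to nitro is the largest step seen so far at this position (a 15-fold lower number from compound 1 to compound 4 (1.18 log units; beyond the scatter)), so the two groups that are not plain alkyl chains stand at opposite ends of the series, and the alkyl compounds 2 and 3 fall in the middle: being non-alkyl does not by itself set the number here. Nothing shown explains this order.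

From the compounds shown here alone, whether a nitrile, an amine or a carboxylic acid on this carbon would land nearer compound 4 or nearer compound 1 remains open, as does whether a longer chain such as propyl would differ from ethyl by more than the scatter. Going by these compounds, all four compounds also share the rest of the core, so it is unknown whether this order would hold if another part of it were changed.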